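The source may report more compounds than this note shows. Statements on the series, on what has been measured and on what is new or still open speak of the compounds shown alone.

Measured in a functional assay on M12 cells (Homo sapiens) for antiproliferative activity, read by WST assay, with a stated time of 72 h; a lower number here means that less compound is needed, a higher number that more compound is needed for the effect:

- Compound 1 `CCCCCCCCCCc1c(C)c(CCCCCCCCCC)c2[n+](c1C)CCC2`: 1.92 uM
- Compound 2 `CCCCCCCC/C=C\c1c(C)c(/C=C\CCCCCCCC)c2[n+](c1C)CCC2`: 3.26 uM
- Compound 3 `CCCCCCCCCCc1c(C)c(CCCCCCCCCC)c2[n+](c1C)CCCC2`: 1.93 uM

The three values lie close together. Compound 2, at 3.26 uM, stands within the usual scatter of both compound 1 and compound 3, so these results do not separate it from either one.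

The next compound to be tested is compound 4 `CCCCCCCC/C=C/c1c(C)c(/C=C/CCCCCCCC)c2[n+](c1C)CCC2`. It has the same atoms and bonds as compound 2 and differs only in configuration as drawn: the two compounds have the same atoms and bonds and differ only in configuration as drawn: 2 of 2 stereo elements differ; a double bond is drawn Z in compound 2 and E in compound 4; a double bond is drawn Z in compound 2 and E in compound 4.

Among the compounds with values here, no step between measured compounds is available as a guide for such a change. The only indication is the narrow spread of values, with compound 1 at 1.92 uM and compound 3 at 1.93 uM. On that basis, no change beyond the scatter is expected in this assay, and the direction is left open. The estimated change is a 1.2-fold lower number from compound 2 to compound 4 (0.07 log units; within the scatter). For compound 4 the expected value is 2.8 uM, with an estimated range of 1.3 uM to 6 uM.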

Compound 4, concentration for half-maximal effect: 2.18 uM
The estimate for compound 4 lay 1.3-fold (0.11 log units) above the measured number; measured number inside the range.
By their numbers in this assay, from the lowest: compounds 1, 3, 4 and 2 (each within the scatter of the next).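

Within the data shown here, this pair gives the first step that changes configuration and nothing else, and it changes both double bonds together. In this assay, going from Z to E at both double bonds gives a 1.5-fold lower number from compound 2 to compound 4 (0.17 log units; within the scatter), so at these chain positions the drawn geometry of the double bonds has no effect that can be told apart from the scatter. The comparison bears on configuration alone, and it rests on one point: the fact that compounds 2 and 4 differ only in the configuration as drawn.

The compounds shown leave open whether a single Z or E double bond, with the other chain unchanged, would read the same way. They also leave open how this assay would respond to a shorter chain, or to an amine or a carboxylic acid at the end of each chain.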